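This account rests on a few compounds, and the source may have more. Where it says the series, first, only, none or still open, it means among the compounds named here.

Measured compounds:
- compound 1, `Cc1c(OCCCCOc2ccc(C(=O)O)cc2)ccc(C(=O)CC2CCCC2)c1C`: "not determined" (no result reported)
- compound 2, `Cc1c(OCCCCOc2cccc(C(=O)O)c2)ccc(C(=O)CC2CCCC2)c1O`: 451 nM
- compound 3, `Cc1c(OCCCCOc2cccc(C(=O)O)c2)ccc(C(=O)CC(C)C)c1C`: "not active" (no number reported)

In an assay on HEK293 cells for positive allosteric modulation of metabotropic glutamate receptor 2 (Rattus norvegicus), read by thallium flux, with a stated time of 2.5 min (on this read-out lower numbers stand for an effect already at smaller amounts and higher numbers for an effect only at larger amounts of compound), compound 1 gives "not determined" (no result reported), so it offers no number to compare. In this assay compound 2 gives 451 nM, the only numerical result in the set. In this assay compound 3 gives "not active" (no number reported), which is not a number either; it is one of two entries without a single value, and its position on the scale therefore cannot be pinned down, only that it lies beyond what the assay reports as a value.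

Compound 4, `Cc1c(OCCCCOc2ccccc2C(=O)O)ccc(C(=O)CC(C)C)c1C`, is the unmeasured partner. It differs from compound 3 in one place: 2-carboxyphenyl in place of 3-carboxyphenyl on an oxygen on a saturated carbon. Within the data shown here, no measured pair shows this change, so no size of step in this assay can be quoted. Since compound 3 itself shows no measurable effect, the change would have to bring the compound into the measurable range to register at all, and nothing in the data indicates that. Compound 4 is therefore expected to remain weak or inactive, with an estimated value around 8000 nM, in a range from 1500 nM to 30000 nM.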

Compound 4, half-maximal effective concentration: 976 nM
Estimate against measurement, compound 4: 8.2-fold (0.91 log units) above, and the stated range ends above it.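

Among these compounds, compound 4 gives 976 nM but compound 3 gives "not active" (no number reported) so no step between them can be read. The compounds shown leave open what 2-carboxyphenyl in place of 3-carboxyphenyl does where the starting compound has a numerical value. No supporting data bear on this result.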